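Cytotoxicity notes on the shared core series

The compounds below may be only part of what the source reports. "The series", "measured", "known", "first", "only" and "open" are said of these compounds alone.

Compound 1 `Cn1cc(-c2cc(-c3cc(Cl)cc(OCC4CC4)c3)c(=O)n(-c3cccnc3)c2)c(=O)[nH]c1=O` is measured in an ADME assay on 16HBE14o- cells (Homo sapiens) for cytotoxicity, read by MTT assay, with a stated time of 72 h (a higher number here means that more compound is tolerated, a lower number that less compound is tolerated), only as a limit of the assay, giving > 100000 nM. Compound 2 `O=c1[nH]cc(-c2cc(-c3cc(Cl)c(F)c(OCc4ccccc4Cl)c3)c(=O)n(-c3cccnc3)c2)c(=O)[nH]1` is likewise reported in this assay only as a limit, giving > 95000 nM. The two results the limit of > 100000 nM in this assay, at which 1 of the 2 values shown sits, and the limit of > 95000 nM in this assay, at which 1 of the 2 values shown sits, leave compound 1 without a rank against any other compound. Compound 3 `Cn1cc(-c2cc(-c3cc(Cl)cc(OCc4scnc4C(F)(F)F)c3)c(=O)n(-c3cccnc3)c2)c(=O)[nH]c1=O` differs from compound 1 by a group of 9 heavy atoms (4 carbon, 1 nitrogen, 3 fluorine, 1 sulfur; one five-membered aromatic ring with 2 hetero atoms) in place of a group of 3 heavy atoms (3 carbon; one three-membered non-aromatic ring of carbon only), on a saturated chain carbon bound to an oxygen on an aromatic ring. Going by the values given here, no measured step exists in this assay, so the expectation is no change beyond the scatter. Compound 3 is expected to give 100000 nM, between 50000 nM and 200000 nM. The expected step is a number no higher from compound 1 to compound 3 (the limit leaves the size open), most likely again only a limit.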

Compound 3, half-maximal cytotoxic concentration: > 100000 nM
Compound 3 ended at the assay's limit (the forecaster's own chance of this, stated with the estimate: 85%); the middle value lies on the limit itself.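

Compound 1 and compound 3 are both reported only as limits in this assay, so no step between them can be read: the limit of > 100000 nM in this assay, at which 2 of the 3 values shown sit.

The compounds shown leave open whether replacing cyclopropyl changes the tolerated concentration at all, and how compound 1, compound 2 and compound 3 truly rank.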